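Saturated ring enlargement on the biaryl-free amide series

The source may hold more compounds than are shown below. What is called first, only, known or untested is meant among the compounds shown, and "the series" means these compounds.

Measured in an ADME assay (liver) for metabolic stability, with Liver microsome (Homo sapiens) as the target, using microsomes; on this read-out higher numbers stand for a longer-lived compound and lower numbers for a shorter-lived compound:
- Compound 1 `CCc1nc2cc(Cl)ccn2c1C(=O)NCc1ccc(-c2ccc(C(=O)O)cc2)cc1` gives > 2 h, which is a limit of the assay.
- Compound 2 `CCc1nc2cc(Cl)ccn2c1C(=O)NCc1ccc(-c2ccncc2)cc1` gives 0.482 h.
- Compound 3 `CCc1nc2cc(Cl)ccn2c1C(=O)NCc1ccc(N2CCCCC2)cc1` gives 0.22 h.

Compound 3 holds the lowest number of the series, and the gap to its nearest neighbour is a 2.2-fold lower number from compound 2 to compound 3 (0.34 log units; beyond the scatter). The next change gives compound 4 `CCc1nc2cc(Cl)ccn2c1C(=O)NCc1ccc(N2CCCCCC2)cc1`, with azepan-1-yl in place of piperidin-1-yl on an aromatic carbon.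

Two measured steps at this same carbon bear on the change. The closer one is a 2.2-fold lower number from compound 2 to compound 3 (0.34 log units; beyond the scatter), and the larger one, resting on a limit, is an at least 9.0-fold lower number from compound 1 to compound 3 (0.95 log units; beyond the scatter). For the measured compounds named here, both swap one group for a very different group, while here only the size of the saturated ring changes, and no measured step isolates that. In this assay no step beyond the scatter is therefore expected, with any drift toward a lower number. The expected step is a 1.2-fold lower number from compound 3 to compound 4 (0.09 log units; within the scatter). Compound 4 is estimated at 0.18 h, with an expected range of 0.09 h to 0.35 h.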

Compound 4, half-life: 0.0483 h
Estimate against measurement, compound 4: 3.7-fold (0.57 log units) above; measured number outside the range, below it.
By their numbers in this assay, from the lowest: compound 4; then compound 3; then compound 2. At a limit, above all of these: compound 1.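

In this assay, for the compounds shown here, the size of the saturated ring at this position matters on its own: azepan-1-yl in place of piperidin-1-yl gives a 4.6-fold lower number from compound 3 to compound 4 (0.66 log units; beyond the scatter), the first step here in which only ring size changes. Against the aromatic pyridin-4-yl, the azepan-1-yl ring gives a 10-fold lower number from compound 2 to compound 4 (1.00 log units; beyond the scatter), which places compound 4 lowest among the compounds with numerical values. Compound 1 stands at a limit, so an at least 41-fold lower number from compound 1 to compound 4 (1.61 log units; beyond the scatter) is a bound and not an exact step: the limit of > 2 h in this assay, at which 1 of the 4 values shown sits.

With only two saturated rings shown, it remains open whether the number follows ring size in general or reflects azepan-1-yl in particular, and pyrrolidin-1-yl would test the smaller side of that trend. Morpholin-4-yl, with a ring oxygen, would show whether a hetero atom added to a six-membered ring shifts the number from that of compound 3.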